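The compounds below may be only part of what the source reports. "The series", "measured", "known", "first", "only" and "open" are said of these compounds alone.

Measured in an ADME assay for pharmacokinetics, read by LC-MS, in phosphate buffer, with a stated time of 120 min, at pH 7.4, tested at 1 uM, in the presence of a further agent that is not named here; a lower number here means that the compound disappears faster, a higher number that the compound lasts longer:
- Compound 1 `C/C=C/C(=O)Nc1ccccc1`: > 8.53 h
- Compound 2 `O=C(/C=C/C(F)F)Nc1ccccc1`: 0.733 h

Compound 1 stands only at a limit: the limit of > 8.53 h in this assay, at which 1 of the 2 values shown sits. There is therefore no exact starting number for this series.

Compound 3 `O=C(/C=C/CN1CCCCC1)Nc1ccccc1` is not yet measured in this assay. It differs from compound 1 on the chain: piperidin-1-yl in place of hydrogen on a saturated chain carbon bound to a double-bonded chain carbon.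

Going by the values given here, only one measured step bears on this change: an at least 11-fold lower number from compound 1 to compound 2 (1.06 log units; beyond the scatter). That step is large and beyond the scatter, and it also alters the chain, with difluoromethyl in place of methyl. It is a loose guide, since piperidin-1-yl is a different group and a single pair sets no pattern. A move in the same direction is expected for compound 3, to a lower number, but of smaller size than the step seen for compound 2.

The expected change is an at least 2.8-fold lower number from compound 1 to compound 3 (0.45 log units; beyond the scatter).

For compound 3 the estimated half-life is 3 h, with an expected range from 0.8 h to 9 h.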

Compound 3, half-life: 2.95 h
The estimate for compound 3 lay 1.0-fold (0.01 log units) above the measured number, and the stated range covers the measured number.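

In this assay a second change on the chain now gives an at least 2.8-fold lower number from compound 1 to compound 3 (0.46 log units; beyond the scatter) with piperidin-1-yl in place of hydrogen on a saturated chain carbon bound to a double-bonded chain carbon. The drop seen with difluoromethyl, which gave an at least 11-fold lower number from compound 1 to compound 2 (1.06 log units; beyond the scatter), is therefore not the only case: both changes on the chain point the same way, and neither compound goes against this, although two steps set only a narrow pattern. Going by these compounds, the true size of both steps stays open, because compound 1 stands at a limit: the limit of > 8.53 h in this assay, at which 1 of the 3 values shown sits.

The two steps share a starting point that is not an exact number, so their sizes cannot be ranked against each other, and it remains unclear whether the lower number belongs to piperidin-1-yl itself or would follow any group placed on this carbon. A smaller amine such as dimethylamino, or morpholin-4-yl with its ring oxygen, at the same place would test whether the ring or the amine nitrogen tracks with the half-life.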